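Cyclopropyl to thiophen-2-yl on the eight-membered amidine series

This account rests on a few compounds, and the source may have more. Where it says the series, first, only, none or still open, it means among the compounds named here.

Measured compounds in a functional assay on the whole organism (plasma, strain Sprague-Dawley) with Rattus norvegicus as the target, with a stated time of 2 h, at a dose of 12.5 mg/kg by the oral route; a higher number here means a stronger effect of the compound at the dose given, a lower number a weaker effect:
- compound 1, `c1ccc(C(/N=C2\CCCCCCN2)C2CC2)cc1`, 0%
- compound 2, `c1ccc(C(/N=C2\CCCCCN2)C2CCC2)cc1`, 14%
- compound 3, `c1ccc(C(/N=C2\CCCCCN2)c2cccs2)cc1`, 23%

Compound 1 stands lowest of the three numbers in this assay. Its nearest neighbour in value is compound 2, and the gap is beyond the scatter; the furthest is compound 3, also beyond the scatter. Among the measured compounds shown here, compound 1 and compound 2 differ in two places at once, so their values are only noted side by side and no single step is drawn between them.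

The compound not yet measured is compound 4, `c1ccc(C(/N=C2\CCCCCCN2)c2cccs2)cc1`. Relative to compound 1 the change is thiophen-2-yl in place of cyclopropyl on a saturated chain carbon bound to an aromatic carbon and a double-bonded nitrogen.

For the measured compounds named here, one measured step bears on this change: a number 9 percentage points higher from compound 2 to compound 3 (within the scatter). That step also puts thiophen-2-yl onto the same saturated chain carbon, though the group it replaces is cyclobutyl and the ring of the shared core differs in size, so it is only a partial precedent. On that basis a small rise, or no step beyond the scatter, is expected for compound 4 in this assay, namely a number 10 percentage points higher from compound 1 to compound 4 (within the scatter). Compound 4 is accordingly estimated at 10%, with a range of 0% to 25%.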

Compound 4, a percentage reported as inhibition, in the whole organism at one dose (the size of the read-out at that dose, not a potency): 29%
For compound 4 the middle estimate is 19 percentage points below the measured one; measured number outside the range, above it.
By their numbers in this assay, from the lowest: compound 1; then compounds 2, 3 and 4 (each within the scatter of the next, the first and the last beyond it).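

In this assay, among the compounds shown here, thiophen-2-yl in place of cyclopropyl on the saturated chain carbon bound to an aromatic carbon and a double-bonded nitrogen gives a number 29 percentage points higher from compound 1 to compound 4 (beyond the scatter) and is the first single-place change at this carbon to clear the scatter. For the compounds shown here, the only earlier step of this kind, from cyclobutyl to thiophen-2-yl on a different core, gave a number 9 percentage points higher from compound 2 to compound 3 (within the scatter) and could not show this, while the two thiophen-2-yl compounds, compound 3 at 23% and compound 4 at 29%, lie within the scatter of each other. No measurement shown accounts for the step, so its origin stays unassigned.

The read-out is a single-dose effect and not a potency, so the step says nothing about how the two compounds would compare at other doses. From the compounds shown here alone, it also remains open whether the step is specific to thiophen-2-yl or would also appear with thiophen-3-yl, furan-2-yl, an unsubstituted phenyl or an open isopropyl chain on the same carbon, and whether an amine on the phenyl ring would change the picture.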